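The source may report more compounds than this note shows. Statements on the series, on what has been measured and on what is new or still open speak of the compounds shown alone.

Measured in a functional assay on KB cells (Homo sapiens) for antiproliferative activity, read by sulforhodamine B assay, with a stated time of 48 h; on this read-out higher numbers stand for weaker inhibition of growth and lower numbers for stronger inhibition of growth:
- compound 1 `COc1ccc(S(=O)(=O)Nc2ccccc2CCc2ccc(C(=O)NO)cc2)cc1`: > 10000 nM (a limit)
- compound 2 `Nc1ccccc1NC(=O)c1ccc(CCc2ccccc2NS(=O)(=O)c2ccc(Cl)cc2)cc1`: 448 nM

Compound 1 has no number of its own and stands only at a limit, (the limit of > 10000 nM in this assay, at which 1 of the 2 values shown sits). Compound 2 does give a number, 448 nM.

Next in the series is compound 3 `COc1ccc(S(=O)(=O)Nc2ccccc2CCc2ccc(C(=O)Nc3cccc(N)c3)cc2)cc1`, not yet measured. It keeps the core of compound 1 and carries 3-aminophenyl in place of hydroxy on an amide-type nitrogen. Among the compounds with values here, no measured pair isolates this change, so its size cannot be read directly.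

The expectation starts from compound 1, whose entry of > 10000 nM is a limit. No step beyond the scatter is expected in this assay, and no direction can be favoured with confidence. The expected change is a number no higher from compound 1 to compound 3 (the limit leaves the size open). A further limit is the most likely report. If a number is obtained, compound 3 is estimated at 10000 nM, with an expected range of 3000 nM to 30000 nM.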

Compound 3, concentration for 50% growth inhibition: 697 nM
Compound 3: the middle estimate sits 14-fold (1.16 log units) above what was measured; measured number below the stated range.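

In this assay, 3-aminophenyl in place of hydroxy on the amide-type nitrogen gives an at least 14-fold lower number from compound 1 to compound 3 (1.15 log units; beyond the scatter). Within the data shown here, this is the first measured change at this position, and it shows that the hydroxycarbamoyl end of compound 1 is not needed for a measurable number on the shared core, since compound 3, with a (3-aminophenyl)carbamoyl end, gives 697 nM. The true size of the step stays unknown, and the printed size is only a lower bound, because the entry for compound 1 is a limit and not a number: the limit of > 10000 nM in this assay, at which 1 of the 3 values shown sits.

The change swaps a single oxygen for a whole aromatic ring carrying an amine, so the compounds shown do not separate the contribution of the ring from that of its amino group; a plain phenyl or a 3-hydroxyphenyl on the same nitrogen would make that split. Compound 2 differs from compound 3 in more than one place, so it cannot show whether the result at this nitrogen depends on the rest of the molecule, and a methyl on the amide nitrogen also remains an open variation.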